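The source may hold more compounds than are shown below. What is called first, only, known or untested is meant among the compounds shown, and "the series" means these compounds.

Working notes on the series. Compound 1 `Cc1cccc(C(=O)c2c(OCC(=O)Nc3ccc(S(N)(=O)=O)cc3C)ccc3ccccc23)c1` and compound 2 `Cc1cc(S(N)(=O)=O)ccc1NC(=O)COc1ccc2ccccc2c1C(=O)c1cccc(Cl)c1` share one core and differ in a single substituent. In an ADME assay on C8166 cells (Homo sapiens) for cytotoxicity, read by colorimetric assay and MTT assay (on this read-out lower numbers stand for higher toxicity in this test and higher numbers for lower toxicity in this test), compound 1 gives 40400 nM. In this assay compound 2 gives 37400 nM. The step of a 1.1-fold lower number from compound 1 to compound 2 (0.03 log units; within the scatter) is chloro in place of methyl on an aromatic carbon; the two numbers lie within the scatter of each other, so compound 2 cannot be placed above or below compound 1 on what is shown.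

Compound 3 `Cc1cc(C)cc(C(=O)c2c(OCC(=O)Nc3ccc(S(N)(=O)=O)cc3C)ccc3ccccc23)c1` is not yet measured. Against compound 2 the change is 3,5-dimethylphenyl in place of 3-chlorophenyl on a carbonyl carbon. Among the compounds with values here, the only measured step that bears on this position is a 1.1-fold lower number from compound 1 to compound 2 (0.03 log units; within the scatter), a change of substituent on the same aromatic ring that stayed within the scatter. Within the data shown here, no measured step covers a second methyl group, so the expectation rests on that one step alone. The expected step of a 1.0-fold higher number from compound 2 to compound 3 (0.01 log units; within the scatter) is none beyond the scatter. Compound 3 is therefore estimated at 38000 nM, with a range of 19000 nM to 76000 nM.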

Compound 3, half-maximal cytotoxic concentration: 39100 nM
For compound 3 the middle estimate is 1.0-fold (0.01 log units) below the measured one; low and high end bracket the measured number.
By their numbers in this assay, from the lowest: compounds 2, 3 and 1 (each within the scatter of the next).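

In this assay, the step of a 1.0-fold lower number from compound 1 to compound 3 (0.01 log units; within the scatter) is methyl in place of hydrogen on an aromatic carbon, so a second methyl group adds a change that the earlier pair did not cover, and it stays within the scatter. The step of a 1.0-fold higher number from compound 2 to compound 3 (0.02 log units; within the scatter), 3,5-dimethylphenyl in place of 3-chlorophenyl on a carbonyl carbon, is also within the scatter, so all three compounds remain unordered across these changes to the aryl group. Nothing available explains why these changes leave the number within the scatter.

Methyl and chloro are the only substituents shown on this ring, so it remains open whether any group here can move the number beyond the scatter. An amine, a carboxylic acid or a methoxy group on this ring would test that, as would a cyclohexyl group in place of the aromatic ring.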